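A few compounds are considered here, and "the series" means these few. Any claim that something is new, unique, unknown or untested is made for them only; others in the source may bear on it.

Measured compounds:
compound 1 `CN(C)CCn1cnnc1-c1cc(Oc2ccc(NC(=O)N/N=C/c3c(Cl)cccc3Cl)cc2F)ccn1` — in a functional assay on A549 cells (Homo sapiens) for cytotoxicity, read by MTT assay, with a stated time of 72 h (on this read-out lower numbers stand for stronger inhibition and higher numbers for weaker inhibition), compound 1 gives 1410 nM
compound 2 `COc1ccc(/C=N/NC(=O)Nc2ccc(Oc3ccnc(-c4nncn4CCN(C)C)c3)c(F)c2)c(OC)c1` — compound 2 gives 2820 nM
compound 3 `CN(C)CCn1cnnc1-c1cc(Oc2ccc(NC(=O)N/N=C/c3ccccc3)cc2F)ccn1` — compound 3 gives 1860 nM

Compound 3 stands second highest of the three numbers; its nearest neighbour is compound 1, its furthest compound 2, and both gaps lie within the scatter: a 1.3-fold higher number from compound 1 to compound 3 (0.12 log units; within the scatter) and a 1.5-fold lower number from compound 2 to compound 3 (0.18 log units; within the scatter). All three compounds share the same core and differ only in the aryl group on the carbon with a double bond to nitrogen.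

Compound 4 `COc1ccc(/C=N/NC(=O)Nc2ccc(Oc3ccnc(-c4nncn4CCN(C)C)c3)c(F)c2)cc1O` continues this series: 3-hydroxy-4-methoxyphenyl in place of phenyl on a carbon with a double bond to nitrogen. Going by the values given here, the steps that bear on it are the three aryl swaps on that same carbon, a 2.0-fold higher number from compound 1 to compound 2 (0.30 log units; within the scatter), a 1.3-fold higher number from compound 1 to compound 3 (0.12 log units; within the scatter) and a 1.5-fold lower number from compound 2 to compound 3 (0.18 log units; within the scatter), none of which moved the number beyond the scatter. Substitution on this ring has so far left the read-out flat, so no step beyond the scatter is expected in this assay for compound 4 either, in either direction. The expected step is a 1.1-fold higher number from compound 3 to compound 4 (0.03 log units; within the scatter). Compound 4 is estimated at 2000 nM, with a range from 900 nM to 4500 nM.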

Compound 4, half-maximal inhibitory concentration: > 100000 nM
Compound 4: a limit, no number; the forecaster's own chance of this, stated with the estimate: 5%; middle value at least 50-fold (1.69 log units) away from the limit.
By their numbers in this assay, from the lowest: compounds 1, 3 and 2 (each within the scatter of the next). At a limit, above all of these: compound 4.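

In this assay compound 4 gives > 100000 nM, a limit and not a number. This position, flat across phenyl, 2,4-dimethoxyphenyl and 2,6-dichlorophenyl, does respond to substitution: 3-hydroxy-4-methoxyphenyl brings an at least 53-fold higher number from compound 3 to compound 4 (1.73 log units; beyond the scatter), along with an at least 35-fold higher number from compound 2 to compound 4 (1.54 log units; beyond the scatter) and an at least 70-fold higher number from compound 1 to compound 4 (1.85 log units; beyond the scatter). Compound 2 also carries methoxy groups on this ring yet lies within the scatter of compound 3, so methoxy substitution as such does not go with the loss, and the hydroxy group is the one feature found only in compound 4.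

Going by these compounds, whether the hydroxy group alone accounts for the loss, or whether a 3-hydroxyphenyl, 3-aminophenyl or 3-carboxyphenyl ring would read the same way, remains open. The full size of the change also remains open, since the reading for compound 4 stops at a limit: the limit of > 100000 nM in this assay, at which 1 of the 4 values shown sits.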